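The compounds below may be only part of what the source reports. "The series", "measured", "known", "first", "only" and "open" are said of these compounds alone.

Of the compounds shown here, two built on a shared core have so far been tested in an assay on cells for inhibition of thyroid peroxidase (Homo sapiens), with stated times of 10 min and 15 min; a lower number here means a stronger inhibitor, a higher number a weaker inhibitor. Compound 1 `Nc1cc(Cc2ccn(Cc3cccc(Cc4ccccc4)c3)n2)c2nn[nH]c2n1` gives 1900 nM in this assay, the lower of the two numbers recorded. Compound 2 `Nc1cc(Cc2ccn(Cc3ccc4c(c3)CCNC4)n2)c2nn[nH]c2n1` gives 6700 nM in this assay, a higher number than compound 1 by a margin that lies beyond the usual scatter, so compound 1 stands as the stronger inhibitor of the pair.

Compound 3 `Nc1cc(Cc2ccn(Cc3cccc(O[C@H]4CCNC4)c3)n2)c2nn[nH]c2n1` has not yet been measured. It differs from compound 1 in a single place: (pyrrolidin-3-yl)oxy in place of benzyl on an aromatic carbon. Going by the values given here, no measured pair shows exactly this change, so the expectation rests on what the two measured compounds reveal. Among the compounds with values here, the only comparison available, compound 2 at 6700 nM, shows that altering the outer group on this ring away from what compound 1 carries has gone with a weaker result. On that basis the step from compound 1 to compound 3 is expected to run toward a higher number, by roughly a 2.1-fold higher number from compound 1 to compound 3 (0.32 log units; beyond the scatter), though not far beyond the scatter. Compound 3 is therefore expected to come in at about 4000 nM, with a likely range from 1500 nM to 11000 nM.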

Compound 3, half-maximal inhibitory concentration: 14000 nM
The estimate for compound 3 lay 3.5-fold (0.54 log units) below the measured number; measured number outside the range, above it.
By their numbers in this assay, from the lowest: compound 1; then compound 2; then compound 3.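

In this assay, going by these compounds alone, putting (pyrrolidin-3-yl)oxy in place of benzyl on the aromatic carbon, meta to a large group, gives a 7.4-fold higher number from compound 1 to compound 3 (0.87 log units; beyond the scatter), the first reading of a single change at this position, and it shows that the position is sensitive to which group it carries. The two groups are close in heavy-atom count, yet the number does not stay near that of compound 1, so a similar count of atoms alone does not preserve the result. The change replaces an aromatic ring of carbon only with a five-membered non-aromatic ring holding a hetero atom, and it adds hydrogen-bond donor and acceptor sites that benzyl lacks, but no measurement here ties the rise to any one of these differences.

On these data alone, the ring, the ether oxygen and the ring nitrogen all change together in this step, so their separate contributions remain unknown. A phenoxy group would keep the aromatic ring with an oxygen link, and a cyclopentyloxy group would keep the oxygen and a five-membered ring without the nitrogen, so each would help separate these contributions.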